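A Thiophene Exchange on the Carbonyl of Compound 3

A few compounds are considered here, and "the series" means these few. Any claim that something is new, unique, unknown or untested is made for them only; others in the source may bear on it.

Among the measured compounds shown here, in a functional assay on HUVEC cells (Homo sapiens), read by BrdU incorporation, with a stated time of 72 h (on this read-out higher numbers stand for weaker inhibition and lower numbers for stronger inhibition), compound 3 `Cc1ccc2nc(Cl)c(/C=C/C(=O)c3cc(C)sc3C)cc2c1` gives 229 nM, the highest number of the three measured so far. Compound 1 `Cc1ccc2cc(/C=C/C(=O)c3ccc(Br)s3)c(Cl)nc2c1` gives 83.6 nM and compound 2 `Cc1ccc2cc(/C=C/C(=O)c3ccc(Cl)s3)c(Cl)nc2c1` gives 49.5 nM. Compound 4 `Cc1csc(C(=O)/C=C/c2cc3cc(C)ccc3nc2Cl)c1` keeps the shared core but carries 4-methylthiophen-2-yl in place of 2,5-dimethylthiophen-3-yl on a carbonyl carbon. For the measured compounds named here, no measured step covers this exchange. Going by the values given here, the only measured step, a 1.7-fold lower number from compound 1 to compound 2 (0.23 log units; within the scatter), is chloro in place of bromo on an aromatic carbon, so it bears on the question only indirectly. Its small size suggests that this pair can be read together. Their structures show the thiophene joined to the carbonyl as in the entering group, and the expectation rests on compound 1 at 83.6 nM and compound 2 at 49.5 nM. A move toward stronger inhibition in this assay is therefore expected, namely a 2.3-fold lower number from compound 3 to compound 4 (0.36 log units; beyond the scatter). For compound 4 the estimated value is 100 nM, with an expected range of 40 nM to 250 nM.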

Compound 4, half-maximal inhibitory concentration: 106 nM
The estimate for compound 4 lay 1.1-fold (0.03 log units) below the measured number; low and high end bracket the measured number.
By their numbers in this assay, from the lowest: compounds 2, 1 and 4 (each within the scatter of the next, the first and the last beyond it); then compound 3.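

In this assay, among the compounds shown here, the exchange of 2,5-dimethylthiophen-3-yl for 4-methylthiophen-2-yl on a carbonyl carbon brings a 2.2-fold lower number from compound 3 to compound 4 (0.33 log units; beyond the scatter) and gives the first measured step at this position. Unlike the earlier step, which lay within the scatter and concerned only chloro in place of bromo on an aromatic carbon, this one lies beyond the scatter and shows that the choice of thiophene on the carbonyl carbon can change the number in this assay. No measurement at hand gives a reason for the step.

The compounds shown leave open whether the step follows from the changed attachment of the thiophene or from the changed methyl groups. They also leave open what an amine or a carboxylic acid on this carbonyl carbon, in place of a thiophene, would give.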